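Carbamoyl for trifluoromethyl on the anilide of compound 3

A few compounds are considered here, and "the series" means these few. Any claim that something is new, unique, unknown or untested is made for them only; others in the source may bear on it.

Compound 3 `O=C(Nc1cc(C(F)(F)F)cc(C(F)(F)F)c1)c1cnc(Cl)nc1C(F)(F)F` gives 50 nM in an assay on Jurkat cells for inhibition of cyclic AMP-dependent transcription factor ATF-1 (Homo sapiens) (on this read-out lower numbers stand for stronger inhibition and higher numbers for weaker inhibition), the lowest of the three measured numbers; compound 1 `O=C(Nc1cc(Cl)cc(Cl)c1)c1cnc(Cl)nc1C(F)(F)F` gives 500 nM and compound 2 `CN(C(=O)c1cnc(Cl)nc1C(F)(F)F)c1cc(Cl)cc(Cl)c1` gives 3000 nM. Compound 4 `NC(=O)c1cc(NC(=O)c2cnc(Cl)nc2C(F)(F)F)cc(C(F)(F)F)c1` carries carbamoyl in place of trifluoromethyl on an aromatic carbon. Among the measured compounds shown here, the only single-change step on record is a 6.0-fold higher number from compound 1 to compound 2 (0.78 log units; beyond the scatter), which concerns the amide nitrogen rather than the anilide ring and so does not bear on this change; no measured step alters one ring substituent alone. Compound 1 and compound 3 differ in both ring substituents, and their values show the bis-trifluoromethyl ring giving the lower number. Compound 4 is therefore expected to give 300 nM, within 60 nM to 1500 nM. The expected step is a 6.0-fold higher number from compound 3 to compound 4 (0.78 log units; beyond the scatter), a weakening beyond the scatter.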

Compound 4, half-maximal inhibitory concentration: 3000 nM
The estimate for compound 4 lay 10-fold (1.00 log units) below the measured number; measured number above the stated range.
By their numbers in this assay, from the lowest: compound 3; then compound 1; then compounds 2 and 4 (each within the scatter of the next).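

In this assay, among the compounds shown here, carbamoyl in place of trifluoromethyl on this aromatic carbon gives a 60-fold higher number from compound 3 to compound 4 (1.78 log units; beyond the scatter), the first single-substituent step on the anilide ring. The position is therefore not indifferent to its substituent: this exchange, which brings in a hydrogen-bond donor and acceptor, costs far more than the scatter. No supporting measurement accounts for the size of this step.

Still open, as far as these compounds go, is how other groups at this position would compare, such as a nitrile, an amine or a carboxylic acid. Whether the same exchange at the remaining trifluoromethyl group would give a similar step is also unresolved.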